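Swapping an imidazole amide for a chlorobenzamide: THP-1 tolerance

A few compounds are considered here, and "the series" means these few. Any claim that something is new, unique, unknown or untested is made for them only; others in the source may bear on it.

Compound 1 `COc1ccc(-c2cnc(NC(=O)c3cnc[nH]3)n2C)cc1`: > 100000 nM, a limit of the assay.
Compound 2 `Cc1cccc(C(=O)Nc2ncc(-c3ccccc3)n2C)c1`: > 50000 nM, likewise a limit.

In a toxicity assay on THP-1 cells (Homo sapiens) for inhibition (a lower number here means that less compound is tolerated, a higher number that more compound is tolerated), compound 1 gives > 100000 nM, which is a limit rather than a measured number, as the limit of > 100000 nM in this assay, at which 1 of the 2 values shown sits, records. Compound 2, carrying a different amide on a different core, gives > 50000 nM in this assay, again only a limit, as the limit of > 50000 nM in this assay, at which 1 of the 2 values shown sits, records. Compound 3 `COc1ccc(-c2cnc(NC(=O)c3cccc(Cl)c3)n2C)cc1` differs from compound 1 by 3-chlorophenyl in place of 1H-imidazol-5-yl on a carbonyl carbon. Within the data shown here, no measured pair shows directly what this exchange does in this assay. Since compound 2, with a carbon-only aromatic ring on its carbonyl, also sits at a limit, the exchange is expected to produce no step beyond the scatter in this assay, with compound 3 most likely reported as a limit once more. The expected step of an at least 1.2-fold lower number from compound 1 to compound 3 (0.09 log units; that floor lies within the scatter) is accordingly close to flat. Compound 3 is estimated at 80000 nM, in a range from 30000 nM to 200000 nM.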

Compound 3, half-maximal cytotoxic concentration: > 28000 nM
Compound 3 ended at the assay's limit; the forecaster's own chance of this, stated with the estimate: 75%; the middle value lies beyond the limit too.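

Compound 1 and compound 3 both stand at limits in this assay, and no step can be read between them. The compounds shown leave open whether 3-chlorophenyl in place of 1H-imidazol-5-yl on a carbonyl carbon changes tolerance at all.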